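Compound 3 against compound 2: a smaller anilino group

The source may hold more compounds than are shown below. What is called first, only, known or untested is meant among the compounds shown, and "the series" means these compounds.

Among the compounds with values here, in a functional assay on HEK293 cells for antagonist activity at transient receptor potential cation channel subfamily V member 1 (Rattus norvegicus), read by calcium flux (on this read-out lower numbers stand for stronger inhibition and higher numbers for weaker inhibition), compound 2 `CN(c1nc2c(Nc3ccc(C(F)(F)F)cc3)ncnc2s1)c1c(Cl)cccc1Cl` gives 540 nM, and this is the only number among the values shown. Compound 1 `FC(F)(F)c1ccc(Nc2cccc3sc(Nc4c(Cl)cccc4Cl)nc23)cc1` reaches only a limit of this assay, > 5000 nM. Of the two values shown, compound 1 sits at the limit of > 5000 nM in this assay, at which 1 of the 2 values shown sits. Compound 3 `FC(F)(F)c1ccc(Nc2ncnc3sc(Nc4ccccc4Cl)nc23)cc1` differs from compound 2 in one place: (2-chlorophenyl)amino in place of (2,6-dichlorophenyl)(methyl)amino on an aromatic carbon. Within the data shown here, no measured pair traces this change, and compound 1, which bears a (2,6-dichlorophenyl)amino group on a different core, cannot serve as a step against compound 2 because its core is not the same. With nothing measured on this change, the step of a 1.7-fold higher number from compound 2 to compound 3 (0.22 log units; within the scatter) is expected to be a modest loss, not clearly beyond the scatter. Compound 3 is estimated at 900 nM, with a range from 150 nM to 5000 nM.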

Compound 3, half-maximal inhibitory concentration: 32 nM
For compound 3 the middle estimate is 28-fold (1.45 log units) above the measured one, outside the stated range (below it).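

In this assay, the position on the five-membered aromatic ring, next to the ring nitrogen and next to the ring sulfur, proves highly responsive to its substituent: (2-chlorophenyl)amino in place of (2,6-dichlorophenyl)(methyl)amino gives a 17-fold lower number from compound 2 to compound 3 (1.23 log units; beyond the scatter). Within the data shown here, the single step bundles several differences, since the entering group has one chlorine where the leaving group has two, lacks the methyl and carries a hydrogen-bond donor that the leaving group does not. No measurement shown accounts for the size of this gain.

The compounds shown leave open which of these differences carries the step. On the shared core, (2-chlorophenyl)(methyl)amino and an unsubstituted phenylamino would each help to separate them.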